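A New Carbon Ring Group at the Assay Limit

A few compounds are considered here, and "the series" means these few. Any claim that something is new, unique, unknown or untested is made for them only; others in the source may bear on it.

Measured in an ADME assay on MT4 cells (Homo sapiens) for cytotoxicity, with a stated time of 5 days; on this read-out lower numbers stand for higher toxicity in this test and higher numbers for lower toxicity in this test:
- Compound 1 `CC1CC=C(C(=O)N(c2cc(C#CC(C)(C)C)sc2C(=O)O)C(C)C)CC1`: > 20000 nM, a limit of the assay and not a number
- Compound 2 `CC(C)N(c1cc(C#CC(C)(C)C)sc1C(=O)O)C(=O)[C@H]1CC[C@H](CF)CC1`: > 20000 nM, a limit of the assay and not a number

Compound 2 has no exact reading to start from, since in this assay compound 2 gives only > 20000 nM, which is a limit. The one other result available is also a limit, so compound 2 cannot be ranked against it. Together the two compounds give (the limit of > 20000 nM in this assay, at which 2 of the 2 values shown sit).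

Compound 3 `CC(C)N(C(=O)[C@H]1[C@@H]2CCCC[C@@H]21)c1cc(C#CC(C)(C)C)sc1C(=O)O` keeps the core of compound 2 and changes a single group on a carbonyl carbon: a group of 7 heavy atoms (7 carbon; one three-membered non-aromatic ring of carbon only, one six-membered non-aromatic ring of carbon only) in place of a group of 8 heavy atoms (7 carbon, 1 fluorine; one six-membered non-aromatic ring of carbon only), on a carbonyl carbon. Among the measured compounds shown here, the one measured step bearing on this change is a step that the two limits leave unreadable from compound 1 to compound 2. That step alters the group at the same place, but it has no readable size. For the measured compounds named here, with a step that the two limits leave unreadable from compound 1 to compound 2 as the only guide, no step beyond the usual scatter is expected, and no direction can be given. The estimated change is a step that the limit leaves unreadable from compound 2 to compound 3, a step expected to stay within that scatter. For compound 3 the expected value is 25000 nM, with an estimated range from 10000 nM to 60000 nM.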

Compound 3, half-maximal cytotoxic concentration: > 20000 nM
Compound 3: no number, only a limit; the forecaster's own chance of this, stated with the estimate: 85%; the middle value does not contradict the limit.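

In this assay compound 3 gives > 20000 nM, which is a limit of the assay and not a number. Its steps from compound 1 and from compound 2 therefore cannot be read: the limit of > 20000 nM in this assay, at which 3 of the 3 values shown sit.

On these data alone, whether the different groups on the carbonyl carbon change toxicity in this test at all remains open, and so does their order.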